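Compound 3 to compound 4: bromo in place of fluoro

A few compounds are considered here, and "the series" means these few. Any claim that something is new, unique, unknown or untested is made for them only; others in the source may bear on it.

In a functional assay on NALM-6 cells (Homo sapiens) for cytotoxicity, read by luminescence and CellTiter-Glo, with a stated time of 3 days (a lower number here means a stronger inhibitor, a higher number a weaker inhibitor), compound 3 (`O=C(Nc1cc(C(F)(F)F)cc(C(F)(F)F)c1)c1cc(F)ccc1O`) gives 620 nM. Compound 1 (`O=C(Nc1cc(C(F)(F)F)cc(C(F)(F)F)c1)c1cc(Br)c(-c2ccccc2)cc1O`) gives 840 nM and compound 2 (`O=C(Nc1cc(C(F)(F)F)cc(C(F)(F)F)c1)c1ccc(Br)cc1O`) gives 1200 nM. All three values lie within the scatter of one another, so compound 3 does not separate from either neighbour.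

Compound 4 (`O=C(Nc1cc(C(F)(F)F)cc(C(F)(F)F)c1)c1cc(Br)ccc1O`) keeps the core of compound 3 and carries bromo in place of fluoro on an aromatic carbon, para to a hydroxy group and meta to a large group: bromo in place of fluoro on an aromatic carbon.

Among the compounds with values here, one measured step bears on this change: a 1.9-fold lower number from compound 2 to compound 3 (0.29 log units; within the scatter). That step alters the halogen and its place together, with 5-fluoro-2-hydroxyphenyl replacing 4-bromo-2-hydroxyphenyl. Within the data shown here, no measured pair compares bromo with fluoro at the same place, so the data give no firm direction for the swap. Among the measured compounds shown here, the series so far shows only small differences in this assay, and no step beyond the scatter is expected here. The expected step is a 1.1-fold lower number from compound 3 to compound 4 (0.05 log units; within the scatter), an estimate that stays within the scatter. For compound 4 the estimated value is 550 nM, with an expected range from 220 nM to 1300 nM.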

Compound 4, half-maximal inhibitory concentration: 590 nM
Estimate against measurement, compound 4: 1.1-fold (0.03 log units) below, and the stated range covers the measured number.
By their numbers in this assay, from the lowest: compounds 4, 3, 1 and 2 (each within the scatter of the next, the first and the last beyond it).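

In this assay, within the data shown here, the first comparison of the two halogens at one place, on an aromatic carbon para to a hydroxy group, gives a 1.1-fold lower number from compound 3 to compound 4 (0.02 log units; within the scatter) and so does not separate bromo from fluoro at this position. Where the bromo sits does register, though only modestly: 5-bromo-2-hydroxyphenyl in place of 4-bromo-2-hydroxyphenyl gives a 2.0-fold lower number from compound 2 to compound 4 (0.31 log units; beyond the scatter) and lies beyond the scatter, whereas hydrogen in place of phenyl gives a 1.4-fold lower number from compound 1 to compound 4 (0.15 log units; within the scatter) and leaves the phenyl of compound 1 unseparated from hydrogen on that aromatic carbon. The numbers come with no accompanying measurement that would account for the modest step or for the two steps within the scatter.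

The compounds shown hold only fluoro or bromo at this position, so it remains open whether a nitrile, a methoxy group, an amine or a carboxylic acid there would move the number beyond the scatter in this assay or leave it unchanged. Also open is whether the modest step from moving the bromo recurs with fluoro, since the 4-fluoro-2-hydroxyphenyl counterpart does not stand among these compounds.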